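The source may report more compounds than this note shows. Statements on the series, on what has been measured and on what is new or still open speak of the compounds shown alone.

For the measured compounds named here, compound 2 `O=C(NCCO)c1cc2ccc(OCc3ccccc3)cc2oc1=O` gives the lowest of the two numbers so far in a functional assay on HeLa cells (Homo sapiens) for cytotoxicity, read by MTT assay, with a stated time of 72 h (on this read-out lower numbers stand for stronger inhibition and higher numbers for weaker inhibition), at 14200 nM; its nearest neighbour, compound 1 `CCCOc1ccc2cc(C(=O)NCCO)c(=O)oc2c1`, gives 22600 nM, and the two lie within the scatter of each other. Going by the values given here, the one measured step, a 1.6-fold lower number from compound 1 to compound 2 (0.20 log units; within the scatter), is itself within the scatter. Compound 3 `O=C(NCCO)c1cc2ccc(OCc3cccc(Br)c3)cc2oc1=O` differs from compound 2 by bromo in place of hydrogen on an aromatic carbon. Among the compounds with values here, no measured step concerns a bromo on an aromatic carbon, and the only step known is small, so no change beyond the scatter is expected. Compound 3 is therefore estimated at 11000 nM, between 4500 nM and 28000 nM, a step of a 1.3-fold lower number from compound 2 to compound 3 (0.11 log units; within the scatter) that is expected to be within the scatter.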

Compound 3, half-maximal inhibitory concentration: 17600 nM
The estimate for compound 3 lay 1.6-fold (0.20 log units) below the measured number, within the range that was stated.
By their numbers in this assay, from the lowest: compounds 2, 3 and 1 (each within the scatter of the next).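

In this assay, bromo in place of hydrogen on an aromatic carbon, meta to a large group, gives a 1.2-fold higher number from compound 2 to compound 3 (0.09 log units; within the scatter) and so leaves the number on the benzyl series unmoved beyond the scatter. The larger change, 3-bromophenyl in place of ethyl, gives a 1.3-fold lower number from compound 1 to compound 3 (0.11 log units; within the scatter) and likewise shows no separation at this position.

Still open, on these data alone, is whether an amine or a carboxylic acid on this aromatic ring, in place of bromo, would give a step beyond the scatter. Nothing measured here speaks to the cause of these small steps.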